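The source may hold more compounds than are shown below. What is called first, only, known or untested is meant among the compounds shown, and "the series" means these compounds.

Going by the values given here, compound 1 `Nc1nn(C(=O)Nc2ccc(Cc3ccccc3)cc2)c2ccccc12` is the only compound here with a plain number in a functional assay on UACC-257 cells (Homo sapiens) for inhibition, read by sulforhodamine B assay, with a stated time of 48 h (a higher number here means a weaker inhibitor of growth, a lower number a stronger inhibitor of growth), where compound 1 gives 10000 nM. Compound 2 `COc1ccc(NC(=O)Nc2n[nH]c3ccccc23)cc1` gives > 100000 nM, which is a limit of the assay rather than a number. The other result in the set is thus (the limit of > 100000 nM in this assay, at which 1 of the 2 values shown sits). Compound 3 `CCCCOc1ccc(NC(=O)n2nc(N)c3ccccc32)cc1` differs from compound 1 by butoxy in place of benzyl on an aromatic carbon. Among the compounds with values here, no measured pair shows this change, so its effect is uncertain. The expected step is a 1.5-fold higher number from compound 1 to compound 3 (0.18 log units; within the scatter), towards weaker growth inhibition, though not clearly beyond the usual scatter. Compound 3 is therefore estimated at 15000 nM, between 4000 nM and 60000 nM.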

Compound 3, concentration for 50% growth inhibition: 29200 nM
Beside the measured number, compound 3's estimate is 1.9-fold (0.29 log units) below it, within the range that was stated.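

In this assay, butoxy in place of benzyl on an aromatic carbon gives a 2.9-fold higher number from compound 1 to compound 3 (0.47 log units; beyond the scatter), a modest move towards weaker growth inhibition. This single-place change shows that the group at this position affects the read-out, even though both compounds remain far from strong inhibitors. Nothing shown here explains the step. Going by these compounds, it stays open whether the loss of the ring or the arrival of the oxygen matters more, and how a longer chain such as hexyloxy, an amine or a carboxylic acid would fare at this carbon.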